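Compound 3: pyridin-2-yl replaces 4-(trifluoromethyl)phenyl

The source may hold more compounds than are shown below. What is called first, only, known or untested is meant among the compounds shown, and "the series" means these compounds.

Values so far in an ADME assay on BHK-21 cells (Mesocricetus auratus) for cytotoxicity, read by MTT assay (on this read-out higher numbers stand for lower toxicity in this test and lower numbers for higher toxicity in this test), are these
Compound 1 `CC(=O)c1ccc2c(c1)nc(-c1ccccn1)n2C1CCCCC1` reads >= 100000 nM as a limit
Compound 2 `C/C(=N\NC(N)=S)c1ccc2c(c1)nc(-c1ccc(C(F)(F)F)cc1)n2C1CCCCC1` reads > 100000 nM as a limit

Compound 2 has only a limit in this assay and its reading of > 100000 nM is not a number. Going by the values given here, the one other value, that of compound 1, is a limit too, so the two cannot be ranked. Compound 3 `C/C(=N\NC(N)=S)c1ccc2c(c1)nc(-c1ccccn1)n2C1CCCCC1` differs from compound 2 in one place, with pyridin-2-yl in place of 4-(trifluoromethyl)phenyl on an aromatic carbon and the rest unchanged. Compound 1 also carries pyridin-2-yl, and its reading of >= 100000 nM is a limit. Among the compounds with values here, no measured pair shows this change, and the expected step of an at least 1.1-fold lower number from compound 2 to compound 3 (0.04 log units; that floor lies within the scatter) is estimated to stay within the usual scatter, with a further limit quite possible. In this assay compound 3 is estimated at 90000 nM with a range from 30000 nM to 150000 nM expected.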

Compound 3, half-maximal cytotoxic concentration: 24000 nM
Beside the measured number, compound 3's estimate is 3.8-fold (0.57 log units) above it, and the stated range ends above it.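

In this assay, pyridin-2-yl in place of 4-(trifluoromethyl)phenyl, on the aromatic carbon between two ring nitrogen atoms, gives an at least 4.1-fold lower number from compound 2 to compound 3 (0.61 log units; beyond the scatter), so a change at this position now shows a step beyond the scatter toward higher toxicity in this test. With pyridin-2-yl kept, the group of 7 heavy atoms in place of the group of 3 heavy atoms gives an at least 4.1-fold lower number from compound 1 to compound 3 (0.61 log units; beyond the scatter), so the lower number appears only in the compound that carries both groups. The first step is only a floor, since compound 2 stands at a limit: the limit of > 100000 nM in this assay, at which 1 of the 3 values shown sits.

From the compounds shown here alone, the true size of the second step also stays open, since compound 1 stands at a limit: the limit of >= 100000 nM in this assay, at which 1 of the 3 values shown sits. Whether plain phenyl or pyridin-3-yl at this position would also lower the number remains open.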